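This account rests on a few compounds, and the source may have more. Where it says the series, first, only, none or still open, it means among the compounds named here.

Compound 3 `C[C@H]1CC[C@@H]2[C@@H](OC(=O)[C@]23CC(c2ccc(Br)cc2)N(c2ccccc2)O3)[C@]2(C)C(=O)C=C[C@@]12O` is the most lipophilic of the three measured compounds in a physicochemical assay for lipophilicity (a higher number here means a more lipophilic compound, a lower number a more polar compound), where compound 3 gives 4. Compound 1 `Cc1ccccc1C1=NO[C@]2(C1)C(=O)O[C@@H]1[C@H]2CC[C@H](C)[C@]2(O)C=CC(=O)[C@@]12C` comes nearest, and in this assay compound 1 gives 1.86, a gap beyond the scatter. Compound 2 `C[C@H]1CC[C@@H]2[C@@H](OC(=O)[C@]23CC(c2ccc(C#N)cc2)=NO3)[C@]2(C)C(=O)C=C[C@@]12O` lies furthest away, and in this assay compound 2 gives 1.17, again beyond the scatter.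

Compound 4 `C[C@H]1CC[C@@H]2[C@@H](OC(=O)[C@]23CC(c2cccc(Cl)c2)N(c2ccccc2)O3)[C@]2(C)C(=O)C=C[C@@]12O` differs from compound 3 in one place: 3-chlorophenyl in place of 4-bromophenyl on a saturated ring carbon. Among the compounds with values here, the only measured step that touches an aryl group is a number 0.69 log units lower from compound 1 to compound 2 (beyond the scatter), but that step exchanges a 2-methylphenyl for a 4-cyanophenyl on a different carbon, so it does not directly tell what a 3-chlorophenyl does in place of a 4-bromophenyl. Within the data shown here, no measured pair compares a bromine-bearing ring with a chlorine-bearing ring.

Given that, the expected step is small: a number 0.20 log units lower from compound 3 to compound 4 (within the scatter) is estimated to stay within the scatter. Compound 4 is therefore expected to give about 3.8, most likely between 3.4 and 4.2.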

Compound 4, partition coefficient: 3.87
The estimate for compound 4 lay 0.07 log units below the measured number; the measured number falls inside the stated range.
By their numbers in this assay, from the lowest: compound 2; then compound 1; then compounds 4 and 3 (each within the scatter of the next).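

Within the data shown here, exchanging 4-bromophenyl for 3-chlorophenyl on this saturated ring carbon gives a number 0.13 log units lower from compound 3 to compound 4 (within the scatter) in this assay, the first measured step in which the aryl group at this position changes. At this position, then, a change in both the halogen and its place on the aryl ring leaves a difference that cannot be told apart from repeat-measurement noise. No measurement on hand offers an explanation for this result.

The halogen and its place on the ring change together in this single step, so the compounds shown cannot say what either change does alone, or whether the two offset each other. Going by these compounds, what an amine or a carboxylic acid on this aryl ring would do to the number also stays open.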